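The source may report more compounds than this note shows. Statements on the series, on what has been measured and on what is new or still open speak of the compounds shown alone.

Of the compounds shown here, two of the same core have been tested so far. Compound 1, `Cc1ccc(-c2ccc(F)cc2)n1-c1ccc(-c2nc3ccccc3s2)cc1`, in an ADME assay on MCF-10A cells (Homo sapiens) for cytotoxicity, read by MTT assay, with a stated time of 72 h (on this read-out higher numbers stand for weaker inhibition and lower numbers for stronger inhibition), gives 40000 nM. Compound 2, `Cc1ccc(-c2ccc([N+](=O)[O-])cc2)n1-c1ccc(-c2nc3ccccc3s2)cc1`, in this assay gives 38800 nM. The step of a 1.0-fold lower number from compound 1 to compound 2 (0.01 log units; within the scatter) is the only measured one, and it leaves the two numbers within the scatter of each other; compound 2 cannot be told apart from compound 1 on this read-out.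

Compound 3, `Cc1ccc(-c2ccc([N+](=O)[O-])cc2)n1-c1ccc(-c2nc3ccc(F)cc3s2)cc1`, differs from compound 2 by fluoro in place of hydrogen on an aromatic carbon. Among the compounds with values here, no measured step concerns this position; the one step that exists, a 1.0-fold lower number from compound 1 to compound 2 (0.01 log units; within the scatter), is a different change at a different place and showed no movement beyond the scatter. There is therefore nothing in the numbers to point in either direction for the new fluoro.

On that basis compound 3 is expected to come out close to compound 2, with a step of no change at the digits printed from compound 2 to compound 3 (within the scatter), amounting to no change beyond the scatter. The estimate for compound 3 in this assay is 38800 nM, within a range from 19000 nM to 80000 nM.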

Compound 3, half-maximal inhibitory concentration: 39000 nM
Estimate against measurement, compound 3: 1.0-fold (0.00 log units) below, and the stated range covers the measured number.
By their numbers in this assay, from the lowest: compounds 2, 3 and 1 (each within the scatter of the next).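

Fluoro in place of hydrogen, taking 1,3-benzothiazol-2-yl to 6-fluoro-1,3-benzothiazol-2-yl, gives a 1.0-fold higher number from compound 2 to compound 3 (0.00 log units; within the scatter) in this assay, which is the first measured step at this position on the shared core, and compound 2 and compound 3 cannot be told apart on this read-out. Together with a 1.0-fold lower number from compound 1 to compound 2 (0.01 log units; within the scatter) at the other aromatic ring, it means that each of the two places probed so far has one step, and both steps lie within the scatter, though this rests on a single substitution at each place. No measurement at hand accounts for this result, so the data give no explanation for how this fluoro behaves on this read-out.

The compounds shown leave open whether a different group at this same position, such as an amine, a carboxylic acid or a longer chain like n-butyl, would give a number beyond the scatter of compound 2. They also leave open whether the 6-fluoro group would give the same result with the fluoro of compound 1 on the other ring in place of the nitro.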